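Heteroaryl sulfide exchange in one series: cytotoxicity notes

The compounds below may be only part of what the source reports. "The series", "measured", "known", "first", "only" and "open" are said of these compounds alone.

Measured in a functional assay on C6 cells (Rattus norvegicus) for cytotoxicity, read by MTT assay, with a stated time of 24 h, tested at 50 ug/mL; a higher number here means a weaker effect of the compound at the concentration tested, a lower number a stronger effect:
compound 1 `Cn1nnnc1SCC(=O)N/N=c1/scc(-c2ccccc2)n1-c1ccccc1` gives 56.2%;
compound 2 `Cc1ccc(-c2cs/c(=N/NC(=O)CSc3ncccn3)n2-c2ccccc2)cc1` gives 64.4%;
compound 3 `Cc1ccc(-c2cs/c(=N/NC(=O)CSc3nncn3C)n2-c2ccccc2)cc1` gives 53.8%.

Compound 3 stands lowest of the three numbers; compound 1 lies within the scatter of it, compound 2 beyond it. Compound 4 `Cc1ccc(-c2cs/c(=N/NC(=O)CSc3nnnn3C)n2-c2ccccc2)cc1` differs from compound 3 by 1-methyl-1H-tetrazol-5-yl in place of 4-methyl-4H-1,2,4-triazol-3-yl on a sulfur. Among the measured compounds shown here, no measured step covers this exchange. For the measured compounds named here, the only step at the same sulfur, a number 10.6 percentage points lower from compound 2 to compound 3 (beyond the scatter), was modest. Compound 1, which also carries the 1-methyl-1H-tetrazol-5-yl on a sulfur, gives a value within the scatter of compound 3. A step of no size beyond the scatter is therefore expected, a number 1.2 percentage points higher from compound 3 to compound 4 (within the scatter). Compound 4 is estimated at 55% in this assay, with a range from 44% to 66%.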

Compound 4, a percentage reported as activity, at one concentration (the size of the read-out at that concentration, not a potency): 44.3%
The estimate for compound 4 lay 10.7 percentage points above the measured number, within the range that was stated.
By their numbers in this assay, from the lowest: compounds 4, 3, 1 and 2 (each within the scatter of the next, the first and the last beyond it).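

In this assay, the exchange at this sulfur gives a number 9.5 percentage points lower from compound 3 to compound 4 (within the scatter), so the two five-membered rings are not separated, while the exchange against the six-membered ring gives a number 20.1 percentage points lower from compound 2 to compound 4 (beyond the scatter). Among the compounds shown here, with the 1-methyl-1H-tetrazol-5-yl held fixed, methyl in place of hydrogen on an aromatic carbon gives a number 11.9 percentage points lower from compound 1 to compound 4 (beyond the scatter), the first reading of a change away from the sulfur. No evidence on the origin of these differences is at hand.

From the compounds shown here alone, whether an amine or a carboxylic acid on the heteroaryl group at this sulfur would shift the number remains open. So does the outcome of methoxy in place of that methyl on the aromatic carbon.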